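A few compounds are considered here, and "the series" means these few. Any claim that something is new, unique, unknown or untested is made for them only; others in the source may bear on it.

Measured compounds:
- compound 1, `CC(=O)Nc1ccc(S(=O)(=O)Oc2ccccc2I)cc1`: 27000 nM
- compound 2, `CCC(=O)Nc1ccc(S(=O)(=O)Oc2ccccc2I)cc1`: 8100 nM
- compound 3, `CCCC(=O)Nc1ccc(S(=O)(=O)Oc2ccccc2C(C)C)cc1`: 6600 nM

In a functional assay on MCF7 cells (Homo sapiens) for antiproliferative activity, read by sulforhodamine B assay, with a stated time of 48 h (a lower number here means a stronger inhibitor, a higher number a weaker inhibitor), compound 3 has the lowest of the three numbers given. Its nearest neighbour is compound 2, whose number is higher by an amount within the scatter, so the two cannot be ranked; compound 1 stands furthest away, beyond the scatter. Going by the values given here, the only single-site step available, a 3.3-fold lower number from compound 1 to compound 2 (0.52 log units; beyond the scatter), concerns the saturated chain at the amide and not the substituent on the aryl ring.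

Compound 4, `CCCC(=O)Nc1ccc(S(=O)(=O)Oc2ccccc2I)cc1`, differs from compound 3 by iodo in place of isopropyl on an aromatic carbon. Among the compounds with values here, no measured pair isolates this exchange: compounds 1 and 2 both carry the iodo group together with shorter amide chains, and compound 3 alone carries the isopropyl group. The exchange therefore cannot be calibrated from the data shown, and no step beyond the scatter is expected in this assay; the estimated step is a 1.1-fold lower number from compound 3 to compound 4 (0.04 log units; within the scatter). For compound 4 the expected value in this assay is 6000 nM, with a range from 2500 nM to 15000 nM.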

Compound 4, half-maximal inhibitory concentration: 9700 nM
The estimate for compound 4 lay 1.6-fold (0.21 log units) below the measured number; measured number inside the range.
By their numbers in this assay, from the lowest: compounds 3, 2 and 4 (each within the scatter of the next); then compound 1.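

In this assay, the exchange of isopropyl for iodo on the aromatic carbon can now be read directly on the same amide chain: a 1.5-fold higher number from compound 3 to compound 4 (0.17 log units; within the scatter) does not separate the two groups at this position. With iodo held fixed, a 1.2-fold higher number from compound 2 to compound 4 (0.08 log units; within the scatter) shows no resolved effect of methyl in place of hydrogen two bonds along the chain from the carbonyl carbon, while a 2.8-fold lower number from compound 1 to compound 4 (0.44 log units; beyond the scatter) keeps the longer chain of compound 4 apart from the acetamide of compound 1. No measurement shown here accounts for these results.

From the compounds shown here alone, whether an amine or a carboxylic acid on this aromatic carbon would separate from iodo and isopropyl stays open. So does whether a longer chain at the amide would shift the number, with either iodo or isopropyl in place.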